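The compounds below may be only part of what the source reports. "The series", "measured", "known", "first", "only" and "open" are said of these compounds alone.

Working notes on the series.

Compound 1 `O=c1[nH]cc(S(=O)(=O)Nc2cccc(-c3cn(-c4ccccc4F)nn3)c2)c(=O)[nH]1` gives 16000 nM in a functional assay on SGC-7901 cells (Homo sapiens) for antiproliferative activity, read by MTT assay, with a stated time of 24 h; on this read-out lower numbers stand for stronger inhibition and higher numbers for weaker inhibition. Compound 2 `O=c1[nH]cc(S(=O)(=O)Nc2cccc(-c3cn(-c4cccc(F)c4)nn3)c2)c(=O)[nH]1` reaches only the assay limit, > 20000 nM, in this assay. Compound 3 `O=c1[nH]cc(S(=O)(=O)Nc2ccc(-c3cn(-c4ccccc4F)nn3)cc2)c(=O)[nH]1` gives 7270 nM in this assay, the lowest of the two numbers recorded.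

Compound 1 and compound 3 share the same atoms joined differently; the difference between the two cores is not broken down here.

For the measured compounds named here, the one measured step is 3-fluorophenyl in place of 2-fluorophenyl on an aromatic nitrogen, which gave an at least 1.2-fold higher number from compound 1 to compound 2 (0.09 log units; that floor lies within the scatter). The floor of that step comes from the limit of > 20000 nM in this assay, at which 1 of the 3 values shown sits, so its true size is open; only its direction, if any, is known.

Compound 4 `O=c1[nH]cc(S(=O)(=O)Nc2ccc(-c3cn(-c4cccc(F)c4)nn3)cc2)c(=O)[nH]1` carries the same kind of change on the core of compound 3: 3-fluorophenyl in place of 2-fluorophenyl on an aromatic nitrogen. The place lines of the two changes read the same, so the measured step, an at least 1.2-fold higher number from compound 1 to compound 2 (0.09 log units; that floor lies within the scatter), is taken as the guide. The new step is expected to be a 1.7-fold higher number from compound 3 to compound 4 (0.22 log units; within the scatter), a number somewhat higher than that of compound 3 and possibly reaching the limit. Compound 4 is therefore estimated at 12000 nM in this assay, with an expected range from 5500 nM to 25000 nM.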

Compound 4, half-maximal inhibitory concentration: > 20000 nM
Compound 4 ended at the assay's limit; the forecaster's own chance of this, stated with the estimate: 25%; middle value at least 1.6-fold (0.22 log units) from the limit.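

The change from 2-fluorophenyl to 3-fluorophenyl on the aromatic nitrogen gives an at least 2.7-fold higher number from compound 3 to compound 4 (0.43 log units; beyond the scatter) in this assay, so on this core the number clearly rises with the change. On the other core the floor of the same change lies within the scatter, so the series shows a rise that is firm on one core and merely compatible with the result on the other, and it gives no size for the step on either: the same change on two cores in this assay, an at least 1.2-fold higher number (0.09 log units; that floor lies within the scatter) from compound 1 to compound 2 and an at least 2.7-fold higher number (0.43 log units; beyond the scatter) from compound 3 to compound 4; the limit leaves it open whether they differ What the data do not show is whether the change carries over from one core to the other with the same size, since neither true number is known: the limit of > 20000 nM in this assay, at which 2 of the 4 values shown sit.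

For the compounds shown here, only two fluorophenyl groups on the aromatic nitrogen appear on each core, so how 4-fluorophenyl, a chlorophenyl or unsubstituted phenyl would read in this assay stays open. Also open, on these data alone, is whether an amine or a carboxylic acid on that ring would bring either core clear of the limit.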